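This account rests on a few compounds, and the source may have more. Where it says the series, first, only, none or still open, it means among the compounds named here.

Working notes on the series. Compound 1, `CNC(=O)[C@@]12C[C@@H]1[C@@H](n1cnc3c(NC)nc(C#Cc4ccccc4F)nc31)[C@H](O)[C@@H]2O`, and compound 2, `CCc1ccc(C#Cc2nc(NC)c3ncn([C@H]4[C@H](O)[C@H](O)[C@]5(C(=O)NC)C[C@H]45)c3n2)o1`, share one core. In an assay on CHO cells for displacement of a labelled ligand from adenosine receptor A1 (Homo sapiens), read by scintillation counting, with a stated time of 60 min, tested at 10 uM (on this read-out lower numbers stand for less inhibition and higher numbers for more inhibition at the one concentration tested (going by the name of the read-out)), compound 1 gives 20%, and in this assay compound 2 gives 18%. On these two numbers compound 2 and compound 1 sit together, separated only by a number 2 percentage points lower from compound 1 to compound 2 (within the scatter). Compound 3, `CNC(=O)[C@@]12C[C@@H]1[C@@H](n1cnc3c(NC)nc(C#Cc4nccs4)nc31)[C@H](O)[C@@H]2O`, is not yet measured; its change from compound 2 is 1,3-thiazol-2-yl in place of 5-ethylfuran-2-yl on a triple-bonded carbon. Among the compounds with values here, the one measured step that bears on it is the earlier exchange of the aromatic group on the triple-bonded carbon, a number 2 percentage points lower from compound 1 to compound 2 (within the scatter), which did not move the read-out beyond the scatter. Because a number 2 percentage points lower from compound 1 to compound 2 (within the scatter) was flat, no step beyond the scatter is expected in this assay for the present exchange either, in either direction. The estimate for compound 3 is therefore 18%, with a range from 5% to 35%. This means an expected step of no change at the digits printed from compound 2 to compound 3 (within the scatter).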

Compound 3, a percentage reported as inhibition, at one concentration (the size of the read-out at that concentration, not a potency): 31%
Compound 3: the middle estimate sits 13 percentage points below what was measured, within the range that was stated.
By their numbers in this assay, from the lowest: compounds 2 and 1 (each within the scatter of the next); then compound 3.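

In this assay the group on the triple-bonded carbon can move the read-out: 1,3-thiazol-2-yl in place of 5-ethylfuran-2-yl gives a number 13 percentage points higher from compound 2 to compound 3 (beyond the scatter) and in place of 2-fluorophenyl gives a number 11 percentage points higher from compound 1 to compound 3 (beyond the scatter) on the same core. Of the three groups, only 1,3-thiazol-2-yl carries nitrogen and sulfur in its ring, but the step from compound 2 also removes the ethyl chain, so these two differences cannot be told apart here. No evidence on the origin of this step is at hand.

Still open, on these data alone, is whether the ring nitrogen, the sulfur or the missing ethyl chain goes with the higher number. An ethyl chain or an amine on the thiazole ring, or a pyridine ring on the triple-bonded carbon, would bear on that question.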